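A few compounds are considered here, and "the series" means these few. Any claim that something is new, unique, unknown or untested is made for them only; others in the source may bear on it.

Measured so far in a functional assay on HCT-116 cells (Homo sapiens) for cytotoxicity, read by MTT assay, with a stated time of 72 h; on this read-out higher numbers stand for weaker inhibition and lower numbers for stronger inhibition:
compound 1 `Cc1cc(S(=O)(=O)/N=C(\N)n2nccc2-c2ccccc2)c(SCc2cccc(Cl)c2)cc1Cl` gives 7000 nM;
compound 2 `Cc1cccc(CSc2cc(Cl)c(C)cc2S(=O)(=O)/N=C(\N)n2nc(C)cc2-c2ccccc2)c1` gives 34000 nM;
compound 3 `Cc1cc(-c2ccccc2)n(/C(N)=N/S(=O)(=O)c2cc(C)c(Cl)cc2SCc2cccc(Cl)c2)n1` gives 18000 nM.

Compound 1 has the lowest number of the three, with compound 3 nearest and compound 2 furthest. Compound 4 `Cc1cc(S(=O)(=O)/N=C(\N)n2nccc2-c2ccccc2)c(SCc2ccccc2C)cc1Cl` differs from compound 1 by 2-methylphenyl in place of 3-chlorophenyl on a saturated chain carbon bound to a sulfur, that is, 3-chlorobenzyl to 2-methylbenzyl on the sulfur. The step of a 1.9-fold lower number from compound 2 to compound 3 (0.28 log units; within the scatter) bears on it, since it exchanges chloro and methyl on the same benzyl ring; its reverse would read methyl in place of chloro. The step of a 2.6-fold higher number from compound 1 to compound 3 (0.41 log units; beyond the scatter) concerns a methyl elsewhere and is only indirect. For compound 4 a small increase in this assay is expected, a 1.7-fold higher number from compound 1 to compound 4 (0.23 log units; within the scatter), probably not beyond the scatter. Compound 4 is estimated at 12000 nM, within 5000 nM to 30000 nM.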

Compound 4, half-maximal inhibitory concentration: 16000 nM
Compound 4: the middle estimate sits 1.3-fold (0.12 log units) below what was measured; measured number inside the range.
By their numbers in this assay, from the lowest: compound 1; then compounds 4, 3 and 2 (each within the scatter of the next, the first and the last beyond it).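

In this assay, 2-methylbenzyl in place of 3-chlorobenzyl on the sulfur gives a 2.3-fold higher number from compound 1 to compound 4 (0.36 log units; beyond the scatter), the first change at this benzyl group shown to lie beyond the scatter. The earlier exchange on an aromatic carbon of this group, a 1.9-fold lower number from compound 2 to compound 3 (0.28 log units; within the scatter), stayed within it. Nothing measured here accounts for the step.

The compounds shown do not separate the change of group from the change of its ring position. From the compounds shown here alone, how an amine or a carboxylic acid on this ring, or a longer chain on the sulfur, would read remains open.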